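Adding a Second Methyl to the Benzylidene Ring

The compounds below may be only part of what the source reports. "The series", "measured", "known", "first", "only" and "open" are said of these compounds alone.

Measured compounds:
compound 1 `COc1cc2c(cc1OC)C(=O)/C(=C/c1cccc(C)c1)C2`: 1800 nM
compound 2 `COc1cc2c(cc1OC)C(=O)/C(=C/c1cccc([N+](=O)[O-])c1)C2`: 22000 nM

In a functional assay on Jurkat cells (Homo sapiens) for antiproliferative activity, read by MTT assay (on this read-out lower numbers stand for stronger inhibition and higher numbers for weaker inhibition), compound 1 gives 1800 nM. Compound 1 stands at the lowest of the two numbers; the nearest is compound 2, with a 12-fold higher number from compound 1 to compound 2 (1.09 log units; beyond the scatter). Compound 3 `COc1cc2c(cc1OC)C(=O)/C(=C/c1cc(C)ccc1C)C2` differs from compound 1 by methyl in place of hydrogen on an aromatic carbon. Among the measured compounds shown here, the only measured step, from compound 1 to compound 2, exchanges one group for another of a different kind on the same ring, and so it does not bear on the present change; no measured step follows a methyl entering in place of hydrogen. With nothing to set a direction, the step of a 1.1-fold higher number from compound 1 to compound 3 (0.05 log units; within the scatter) is expected to stay within the scatter, with a wide range. For compound 3 in this assay the estimated value is therefore 2000 nM, between 600 nM and 7000 nM.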

Compound 3, half-maximal inhibitory concentration: 30500 nM
Compound 3: the middle estimate sits 15-fold (1.18 log units) below what was measured, outside the stated range (above it).
By their numbers in this assay, from the lowest: compound 1; then compounds 2 and 3 (each within the scatter of the next).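

A single methyl, one heavy atom with no hydrogen-bond donors or acceptors, placed on an aromatic carbon ortho to a large group and para to the methyl group of compound 1, is enough to weaken inhibition markedly in this assay, with a 17-fold higher number from compound 1 to compound 3 (1.23 log units; beyond the scatter). The earlier step concerned only an exchange of one group for another on the same ring, whereas this one shows that filling a carbon that carried only hydrogen can matter just as much. Nothing available here accounts for the size of this change.

Going by these compounds, whether a fluorine, a methoxy or an amine on this same carbon would raise the number as far remains open. On these data alone, it is also open whether this methyl would have the same effect without the methyl group para to it.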